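Amide side chain and tolerated concentration in the series

The source may report more compounds than this note shows. Statements on the series, on what has been measured and on what is new or still open speak of the compounds shown alone.

Measured compounds:
compound 1 `O=C(O)CCC(=O)Nc1ccc(-c2nc3cc(C(F)(F)F)ccc3[nH]2)cc1` — > 100000 nM
compound 2 `CCC(=O)Nc1ccc(-c2nc3cc(C(F)(F)F)ccc3[nH]2)cc1` — > 100000 nM
compound 3 `CCN(CC)CC(=O)Nc1ccc(-c2nc3cc(C(F)(F)F)ccc3[nH]2)cc1` — 13000 nM

In an ADME assay on MDBK cells (Bos taurus) for cytotoxicity, read by MTT assay, with a stated time of 96 h (a higher number here means that more compound is tolerated, a lower number that less compound is tolerated), compound 1 gives > 100000 nM, which is a limit of the assay and not a number. Compound 2 gives > 100000 nM in this assay, again a limit. Among the measured compounds shown here, compound 3 gives 13000 nM in this assay and is the only compound of the three with a number; the other two sit at the limit of > 100000 nM in this assay, at which 2 of the 3 values shown sit. The step that the two limits leave unreadable from compound 1 to compound 2 therefore cannot be read. The steps of an at least 7.6-fold lower number from compound 1 to compound 3 (0.88 log units; beyond the scatter) and an at least 7.6-fold lower number from compound 2 to compound 3 (0.88 log units; beyond the scatter) both show that entry of diethylamino lowered the number.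

Compound 4 `O=C(CCl)Nc1ccc(-c2nc3cc(C(F)(F)F)ccc3[nH]2)cc1` is not yet measured. It differs from compound 3 by chloro in place of diethylamino on a saturated chain carbon bound to a carbonyl carbon. The two measured steps that bear on it are those in which diethylamino enters; its departure here runs against them and would point to a higher number. For the measured compounds named here, no measured step covers entry of chloro, so the expectation is wide. A step of a 2.3-fold higher number from compound 3 to compound 4 (0.36 log units; beyond the scatter) is expected. Compound 4 is estimated at 30000 nM, within 4000 nM to 100000 nM.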

Compound 4, half-maximal cytotoxic concentration: 17000 nM
The estimate for compound 4 lay 1.8-fold (0.25 log units) above the measured number, and the stated range covers the measured number.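

In this assay the change shows a 1.3-fold higher number from compound 3 to compound 4 (0.12 log units; within the scatter) on the saturated chain carbon bound to a carbonyl carbon, so chloro and diethylamino cannot be told apart at this position. Chloro also gives an at least 5.8-fold lower number from compound 2 to compound 4 (0.76 log units; beyond the scatter) and an at least 5.8-fold lower number from compound 1 to compound 4 (0.76 log units; beyond the scatter), so the lower number at this position no longer belongs to diethylamino alone. Both of these last steps start from a limit of the assay and not a number, for compound 1 and compound 2 alike: the limit of > 100000 nM in this assay, at which 2 of the 4 values shown sit.

Going by these compounds, whether fluoro, a hydroxyl or a ring amine such as morpholine on this carbon would sit with compound 3 and compound 4 or with compound 1 and compound 2 stays open. So does whether a longer chain carrying chloro or diethylamino would keep the number of the shorter one.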